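This account rests on a few compounds, and the source may have more. Where it says the series, first, only, none or still open, it means among the compounds named here.

Measured so far, on the shared core:

Compound 1 `CCCN(CC[C@H]1CC[C@H](NC(=O)/C=C/c2ccc(Cl)cc2)CC1)[C@H]1CCc2nc(N)sc2C1` — 2.5 nM
Compound 2 `CCCN(CC[C@H]1CC[C@H](NC(=O)c2cccc3ncccc23)CC1)[C@H]1CCc2nc(N)sc2C1` — 1.6 nM
Compound 3 `CCCN(CC[C@H]1CC[C@H](NC(=O)c2cccc(-n3ccnc3)c2)CC1)[C@H]1CCc2nc(N)sc2C1` — 1.1 nM

In an assay on brain for displacement of a labelled ligand from D(3) dopamine receptor (Rattus norvegicus) (on this read-out lower numbers stand for stronger inhibition and higher numbers for weaker inhibition), compound 1 gives 2.5 nM, the highest of the three numbers. Its nearest neighbour is compound 2, a 1.6-fold lower number from compound 1 to compound 2 (0.19 log units; within the scatter), and its furthest is compound 3, a 2.3-fold lower number from compound 1 to compound 3 (0.36 log units; beyond the scatter). Compound 4 `CCCN(CC[C@H]1CC[C@H](NS(=O)(=O)c2cccc(Cl)c2)CC1)[C@H]1CCc2nc(N)sc2C1` differs from compound 1 by (3-chlorophenyl)sulfonyl in place of (2-(4-chlorophenyl)ethenyl)carbonyl on an amine nitrogen. Both measured steps that start from compound 1 swap the same leaving group for an aromatic carbonyl, and neither shifts the number far. Among the compounds with values here, no measured step exchanges a carbonyl for a sulfonyl, so that part of the change to compound 4 is untested. Against compound 1, the expected step for compound 4 is a 1.6-fold higher number from compound 1 to compound 4 (0.20 log units; within the scatter), carrying a wide range. The estimate for compound 4 is 4 nM, between 1 nM and 25 nM.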

Compound 4, inhibition constant: 1.1 nM
Beside the measured number, compound 4's estimate is 3.6-fold (0.56 log units) above it; measured number inside the range.
By their numbers in this assay, from the lowest: compounds 3, 4, 2 and 1 (each within the scatter of the next, the first and the last beyond it).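

In this assay, the amine nitrogen of the shared core carries a sulfonyl as well as a carbonyl without any loss: (3-chlorophenyl)sulfonyl in place of (2-(4-chlorophenyl)ethenyl)carbonyl gives a modest gain (a 2.3-fold lower number from compound 1 to compound 4 (0.36 log units; beyond the scatter)). This single step changes the linking group and the aryl part together, so the share of each cannot be separated. Nothing available explains the result.

On these data alone, what a plain phenylsulfonyl or a methylsulfonyl would give on this nitrogen remains open. So does whether the chlorine on the ring contributes to the number.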